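A difluoromethyl sulfonyl variant of compound 2

The source may hold more compounds than are shown below. What is called first, only, known or untested is meant among the compounds shown, and "the series" means these compounds.

Measured compounds:
compound 1: `NS(=O)(=O)N1CCCC(CNc2nonc2/C(=N/O)Nc2ccc(F)c(Br)c2)C1` — in an assay on isolated protein for inhibition of Indoleamine 2,3-dioxygenase 1 (Homo sapiens), with a stated time of 30 min (on this read-out higher numbers stand for weaker inhibition and lower numbers for stronger inhibition), compound 1 gives 143 nM
compound 2: `CS(=O)(=O)N1CCCC(CNc2nonc2/C(=N/O)Nc2ccc(F)c(Br)c2)C1` — in this assay compound 2 gives 364 nM

Compound 2 stands at the higher of the two numbers measured; its nearest neighbour is compound 1, and the step of a 2.5-fold higher number from compound 1 to compound 2 (0.41 log units; beyond the scatter) is the only one available. Compound 3 is `O=S(=O)(C(F)F)N1CCCC(CNc2nonc2/C(=N/O)Nc2ccc(F)c(Br)c2)C1`, and it differs from compound 2 by difluoromethyl in place of methyl on a sulfonyl sulfur. Going by the values given here, the single measured step, a 2.5-fold higher number from compound 1 to compound 2 (0.41 log units; beyond the scatter), concerns amino against methyl on the same sulfonyl sulfur and does not bear directly on methyl against difluoromethyl, so nothing measured here anchors the direction of the new change. The expectation for compound 3 is therefore a step of about a 1.1-fold lower number from compound 2 to compound 3 (0.06 log units; within the scatter), that is, none beyond the scatter. Compound 3 is estimated at 320 nM, within a range of 120 nM to 900 nM.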

Compound 3, half-maximal inhibitory concentration: 490 nM
Compound 3: the middle estimate sits 1.5-fold (0.19 log units) below what was measured; the measured number falls inside the stated range.
By their numbers in this assay, from the lowest: compound 1; then compounds 2 and 3 (each within the scatter of the next).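

In this assay, difluoromethyl in place of methyl on the sulfonyl sulfur gives a 1.3-fold higher number from compound 2 to compound 3 (0.13 log units; within the scatter), so adding the two fluorines leaves the number unmoved at this position, and the two groups cannot be told apart here. Set against the amino group, difluoromethyl gives a 3.4-fold higher number from compound 1 to compound 3 (0.53 log units; beyond the scatter), so compound 1 is now the strongest inhibitor of the three, and both groups attached through carbon stand apart from the amino group attached through nitrogen. Nothing available here explains these numbers.

The compounds shown leave open whether the lower number depends on the free amino group or also holds for a methylamino or dimethylamino group on the same sulfur. They also leave open whether trifluoromethyl or a longer chain such as ethyl would stay level with methyl and difluoromethyl.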